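Compound 2 to compound 4 in a cytotoxicity series

The compounds below may be only part of what the source reports. "The series", "measured", "known", "first", "only" and "open" are said of these compounds alone.

Of the compounds shown here, three have been measured in a functional assay on HT-29 cells (Homo sapiens) for cytotoxicity, read by resazurin assay, with a stated time of 48 h; on this read-out higher numbers stand for an effect only at larger amounts of compound and lower numbers for an effect already at smaller amounts. Compound 1 `O=C(Nc1ccc(Sc2nc3ccccc3s2)cc1)c1cc(Br)cc(Br)c1O` gives 21000 nM, and compound 3 `Nc1ccc(S(=O)(=O)Nc2ccc(-c3nc4cc(NS(=O)(=O)c5ccc(N)cc5)ccc4o3)cc2)cc1` gives 24000 nM. Compound 2 `O=S(=O)(Nc1ccc(-c2nc3cc(NS(=O)(=O)c4ccc(Cl)s4)ccc3o2)cc1)c1ccc(Cl)s1` gives 33000 nM, the highest number of the three, though both compound 3 and compound 1 fall within the usual scatter of it, so no ranking can be drawn. Compound 4 `O=S(=O)(Nc1ccc(-c2nc3cc(NS(=O)(=O)c4ccc(Cl)s4)ccc3o2)cc1)c1ccc(Cl)c(C(F)(F)F)c1` is not yet measured; it differs from compound 2 in one place: 4-chloro-3-(trifluoromethyl)phenyl in place of 5-chlorothiophen-2-yl on a sulfonyl sulfur. Among the compounds with values here, no measured pair differing in a single place exists to guide this change. A step within the scatter is expected, a 1.1-fold lower number from compound 2 to compound 4 (0.04 log units; within the scatter). Compound 4 is therefore estimated at 30000 nM, ranging from 12000 nM to 80000 nM.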

Compound 4, half-maximal effective concentration: 21000 nM
The estimate for compound 4 lay 1.4-fold (0.15 log units) above the measured number; low and high end bracket the measured number.
By their numbers in this assay, from the lowest: compounds 1, 4, 3 and 2 (each within the scatter of the next).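

In this assay this sulfonyl sulfur gives the first single-place comparison, and a 1.6-fold lower number from compound 2 to compound 4 (0.20 log units; within the scatter) shows no readable effect of exchanging 5-chlorothiophen-2-yl for 4-chloro-3-(trifluoromethyl)phenyl. The position thus accepts a six-membered aromatic ring of carbon only, with more heavy atoms, in place of a five-membered aromatic ring with a hetero atom. Nothing given here explains this result. From the compounds shown here alone, whether an amine, a carboxylic acid or a longer chain on this sulfonyl sulfur would move the number beyond the scatter remains open. Also open, going by these compounds, is whether the same exchange at the other sulfonyl sulfur would behave alike.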